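Trading a methoxyphenyl for a dimethyl-oxazolyl group

This account rests on a few compounds, and the source may have more. Where it says the series, first, only, none or still open, it means among the compounds named here.

Three compounds sharing one core have been measured in an assay on CHO cells for displacement of a labelled ligand from adenosine receptor A3 (Homo sapiens), read by scintillation counting, tested at 10 uM; a lower number here means less inhibition, a higher number more inhibition at the concentration tested (going by the name of the read-out):
Compound 1 `CC(C)(C)Cc1c(-c2ccc(F)cc2F)sc(N)c1C(=O)c1ccc(Cl)cc1`: 1%
Compound 2 `CC(C)(C)Cc1c(/C=C/c2ccc(Cl)cc2)sc(N)c1C(=O)c1ccc(Cl)cc1`: 11%
Compound 3 `COc1cccc(-c2sc(N)c(C(=O)c3ccc(Cl)cc3)c2CC(C)(C)C)c1`: 1%

Compound 3 stands level with compound 1 at the digits shown, and together they are the lowest of the three numbers; its nearest neighbour is compound 1, with no change at the digits printed from compound 1 to compound 3 (within the scatter), and its furthest is compound 2, with a number 10 percentage points lower from compound 2 to compound 3 (within the scatter), so all three sit within the usual scatter of one another.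

Compound 4 `Cc1noc(C)c1-c1sc(N)c(C(=O)c2ccc(Cl)cc2)c1CC(C)(C)C` is the next compound to be tested in this assay. It differs from compound 3 in one place: 3,5-dimethyl-1,2-oxazol-4-yl in place of 3-methoxyphenyl on an aromatic carbon.

Every measured step here changes the same group on the same ring carbon, and none of them moved the number beyond the scatter: a number 10 percentage points higher from compound 1 to compound 2 (within the scatter), no change at the digits printed from compound 1 to compound 3 (within the scatter) and a number 10 percentage points lower from compound 2 to compound 3 (within the scatter). Three different groups at this position all gave little inhibition, so no step beyond the scatter is expected from compound 3 to compound 4 either; the estimated step is a number 2 percentage points higher from compound 3 to compound 4 (within the scatter). Compound 4 is therefore expected to give about 3% in this assay, with a range from -7% to 14%.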

Compound 4, a percentage reported as inhibition, at one concentration (the size of the read-out at that concentration, not a potency): 1%
For compound 4 the middle estimate is 2 percentage points above the measured one, within the range that was stated.
By their numbers in this assay, from the lowest: compounds 1, 3, 4 and 2 (each within the scatter of the next).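

In this assay, replacing a six-membered aromatic ring of carbon only with a five-membered aromatic ring with 2 hetero atoms, on the carbon next to the ring sulfur, gives no change at the digits printed from compound 3 to compound 4 (within the scatter) for this swap. The other comparisons read alike, with no change at the digits printed from compound 1 to compound 4 (within the scatter) and a number 10 percentage points lower from compound 2 to compound 4 (within the scatter) as the remaining steps, so compound 4 extends the flat picture at this position to a ring holding nitrogen and oxygen. Nothing available explains this flat picture.

The compounds shown leave open how an amine, a carboxylic acid or a longer alkyl chain would read at this ring carbon. They also leave open whether replacing the neopentyl group, the amino group or the (4-chlorophenyl)carbonyl group would move the number beyond the scatter.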